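The source may hold more compounds than are shown below. What is called first, only, known or untested is meant among the compounds shown, and "the series" means these compounds.

For the measured compounds named here, compound 1 `CS(=O)(=O)c1ccc(C#N)cc1C(=O)N1CCC(N(C2CC2)S(=O)(=O)c2cccc(C(F)(F)F)c2)CC1` is the weaker of the two measured compounds in an assay on HEK293 cells for inhibition of Voltage-dependent N-type calcium channel subunit alpha-1B (Homo sapiens), read by FLIPR and calcium flux (on this read-out lower numbers stand for stronger inhibition and higher numbers for weaker inhibition), where compound 1 gives 670 nM; its only neighbour is compound 2 `CS(=O)(=O)c1ccc(C(=O)N2CCC(N(C3CC3)S(=O)(=O)c3cccc(C(F)(F)F)c3)CC2)c(F)c1`, which in this assay gives 350 nM, and the step of a 1.9-fold lower number from compound 1 to compound 2 (0.28 log units; within the scatter) is too small to call a real difference. Compound 3 `CS(=O)(=O)c1ccc(C(=O)N2CCC(N(C3CC3)S(=O)(=O)c3cccc(C(F)(F)F)c3)CC2)c(Cl)c1` has not yet been measured. Its change from compound 1 is 2-chloro-4-(methylsulfonyl)phenyl in place of 5-cyano-2-(methylsulfonyl)phenyl on a carbonyl carbon. Going by the values given here, the one measured step that bears on this is the one from compound 1 to compound 2, where 2-fluoro-4-(methylsulfonyl)phenyl took the place of the same 5-cyano-2-(methylsulfonyl)phenyl on the carbonyl carbon and the number moved only within the scatter. Among the compounds with values here, compound 3 carries a chlorine where compound 2 carries a fluorine, and no measured pair shows what that exchange does. Within the data shown here, the expectation for compound 3 is therefore a step of a 1.7-fold lower number from compound 1 to compound 3 (0.22 log units; within the scatter) that stays close to the one seen for compound 2, with no movement beyond the scatter being the most likely outcome. On that basis compound 3 is estimated at 400 nM in this assay, within a range from 150 nM to 1100 nM.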

Compound 3, half-maximal inhibitory concentration: 290 nM
Compound 3: middle estimate off by 1.4-fold (0.14 log units), on the high side; the measured number falls inside the stated range.
By their numbers in this assay, from the lowest: compounds 3, 2 and 1 (each within the scatter of the next, the first and the last beyond it).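

In this assay, for the compounds shown here, the exchange of 5-cyano-2-(methylsulfonyl)phenyl for 2-chloro-4-(methylsulfonyl)phenyl on the carbonyl carbon gives a 2.3-fold lower number from compound 1 to compound 3 (0.36 log units; beyond the scatter) and so is the first step in this small set to clear the scatter, though only modestly. Chloro in place of fluoro on the aromatic carbon gives a 1.2-fold lower number from compound 2 to compound 3 (0.08 log units; within the scatter) and so separates neither halogen from the other, which means that compound 2 and compound 3 read as equals in this assay, while only compound 3 stands clearly apart from compound 1. No separate measurement accompanies these numbers to account for them and they describe the size of the steps alone.

The step from compound 1 to compound 3 removes the nitrile, adds the chlorine and changes the place of the methylsulfonyl group all at once, so the compounds shown cannot say which of these parts matters. Also open, going by these compounds, is how a bromine, a methyl or a methoxy group would read in place of the chloro, and whether a hydrogen there would hold the number near that of compound 3.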